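This account rests on a few compounds, and the source may have more. Where it says the series, first, only, none or still open, it means among the compounds named here.

Measured values in a toxicity assay on WI-38 cells (Homo sapiens) for cytotoxicity, read by MTT assay, with a stated time of 48 h; on this read-out higher numbers stand for weaker inhibition and lower numbers for stronger inhibition:

compound 1 `O=C(/C=C/c1ccc2c(c1)B(O)OC2)c1ccc(I)cc1` gives > 100000 nM, which is a limit of the assay.
compound 2 `Cc1ccc(C(=O)/C=C/c2ccc3c(c2)B(O)OC3)cc1` gives 22200 nM.
compound 3 `O=C(/C=C/c1ccc2c(c1)B(O)OC2)c1ccc(O)cc1` gives > 100000 nM, which is a limit of the assay.

Compound 3 thus stands at the top of the measured range in this assay, at the limit of > 100000 nM in this assay, at which 2 of the 3 values shown sit. Going by the values given here, the only step with a readable size that touches compound 3 is an at least 4.5-fold higher number from compound 2 to compound 3 (0.65 log units; beyond the scatter), which accompanies hydroxy in place of methyl on the aromatic carbon. The step that the two limits leave unreadable from compound 1 to compound 3 cannot be sized, and the step of an at least 4.5-fold lower number from compound 1 to compound 2 (0.65 log units; beyond the scatter) links the two other compounds.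

Compound 4 `O=C(/C=C/c1ccc2c(c1)B(O)OC2)c1cccc(F)c1` has not been measured. Relative to compound 3 the change is 3-fluorophenyl in place of 4-hydroxyphenyl on a carbonyl carbon. Among the compounds with values here, the hydroxy that leaves here is the group whose entry gave the step from compound 2 to compound 3, so its removal is read as a move back in the opposite direction; the fluorine that enters has no counterpart among the measured compounds, and the step of an at least 4.5-fold lower number from compound 1 to compound 2 (0.65 log units; beyond the scatter) gives no guide for a halogen at this ring position. The expected step is therefore an at least 2.5-fold lower number from compound 3 to compound 4 (0.39 log units; beyond the scatter), a lowering of the number. Compound 4 is estimated at 40000 nM, with a range from 12000 nM to 100000 nM, and a real chance that only a limit is reported.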

Compound 4, half-maximal inhibitory concentration: 26700 nM
Compound 4: middle estimate off by 1.5-fold (0.18 log units), on the high side; the measured number falls inside the stated range.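

In this assay, the phenyl group on the carbonyl carbon again sets the read-out: 3-fluorophenyl in place of 4-hydroxyphenyl gives an at least 3.7-fold lower number from compound 3 to compound 4 (0.57 log units; beyond the scatter), and 3-fluorophenyl in place of 4-iodophenyl gives an at least 3.7-fold lower number from compound 1 to compound 4 (0.57 log units; beyond the scatter). Replacing 4-methylphenyl with 3-fluorophenyl gives a 1.2-fold higher number from compound 2 to compound 4 (0.08 log units; within the scatter), so these two groups cannot be told apart here, and a value short of the limit no longer rests on 4-methylphenyl alone. The two steps beyond the scatter give minimum sizes only, because compound 1 and compound 3 each carry a limit of the assay rather than a number: the limit of > 100000 nM in this assay, at which 2 of the 4 values shown sit.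

The group and its place on the ring change together between compound 3 and compound 4, so the compounds shown do not separate the effect of losing the hydroxy from that of adding the fluorine or of moving the substituent. As far as these compounds go, it also remains open whether an amine or a carboxylic acid on this phenyl ring would give a value in the range of compound 2 and compound 4 or one at the limit.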